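The source may report more compounds than this note shows. Statements on the series, on what has been measured and on what is new or still open speak of the compounds shown alone.

Measured in a functional assay on a cell-free system (plasma, Homo sapiens), with a stated time of 3 min; on this read-out lower numbers stand for stronger inhibition and higher numbers for weaker inhibition:
Compound 1 `O=C(NCc1cc(Cl)ccc1-n1cnnn1)[C@@H]1CC=NN1C(=O)[C@H](O)c1ccccc1F`: 1100 nM
Compound 2 `CC(C)(C)C[C@@H](O)C(=O)N1N=CC[C@H]1C(=O)NCc1cc(Cl)ccc1-n1cnnn1`: 590 nM
Compound 3 `O=C(NCc1cc(Cl)ccc1-n1cnnn1)[C@@H]1CC=NN1C(=O)[C@H](O)Cc1ccccc1`: 1400 nM

Compound 3 stands within the scatter of compound 1, and its number is higher than that of compound 2, a 2.4-fold higher number from compound 2 to compound 3 (0.38 log units; beyond the scatter). Compound 4 `CC(C)CC[C@@H](O)C(=O)N1N=CC[C@H]1C(=O)NCc1cc(Cl)ccc1-n1cnnn1` carries isobutyl in place of phenyl on a saturated chain carbon, two bonds along the chain from a carbonyl carbon and an oxygen on a saturated carbon, so that benzyl becomes isopentyl: isobutyl in place of phenyl on a saturated chain carbon, two bonds along the chain from a carbonyl carbon and an oxygen on a saturated carbon. The closest measured step is the one that put phenyl in place of tert-butyl, a 2.4-fold higher number from compound 2 to compound 3 (0.38 log units; beyond the scatter), and the change to compound 4 runs the opposite way, from a ring back to an open chain. The other two steps, a 1.9-fold lower number from compound 1 to compound 2 (0.27 log units; within the scatter) and a 1.3-fold higher number from compound 1 to compound 3 (0.10 log units; within the scatter), stay within the scatter. A modest move toward a lower number in this assay is therefore expected, and it may not clear the scatter. The expected step is a 1.9-fold lower number from compound 3 to compound 4 (0.27 log units; within the scatter). For compound 4 the estimated value is 750 nM, with an expected range of 330 nM to 1600 nM.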

Compound 4, half-maximal inhibitory concentration: 630 nM
For compound 4 the middle estimate is 1.2-fold (0.08 log units) above the measured one; low and high end bracket the measured number.
By their numbers in this assay, from the lowest: compounds 2, 4, 1 and 3 (each within the scatter of the next, the first and the last beyond it).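

In this assay, among the compounds shown here, isobutyl in place of phenyl at this position gives a step beyond the scatter (a 2.2-fold lower number from compound 3 to compound 4 (0.35 log units; beyond the scatter)), so a second open chain, after the one in compound 2, stands apart from the phenyl of compound 3. The two open chains do not separate from each other (a 1.1-fold higher number from compound 2 to compound 4 (0.03 log units; within the scatter)), and isopentyl does not separate from the 2-fluorophenyl of compound 1 either (a 1.7-fold lower number from compound 1 to compound 4 (0.24 log units; within the scatter)), so the ring-to-chain change clears the scatter only against compound 3, and compound 1 goes against any general rule that rings lose to chains here. No measurement shown offers a reason for these steps.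

On these data alone, it remains open whether a longer chain, or a chain ending in an amine or a carboxylic acid, would keep this level at the same position.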